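This account rests on a few compounds, and the source may have more. Where it says the series, first, only, none or still open, it means among the compounds named here.

Compound 1 `O=C(Nc1ccc(Cl)cn1)C1CCCN(C(=O)c2cc(C(F)(F)F)cc(C(F)(F)F)c2)C1` gives 0% in an ADME assay on PC-3 cells (Homo sapiens) for cytotoxicity, read by WST assay, tested at 100 uM; on this read-out higher numbers stand for more inhibition at the one concentration tested (going by the name of the read-out) and lower numbers for less inhibition.
Compound 2 `O=C(Nc1ccc(Cl)cc1)C1CCCN(C(=O)c2cccc(-c3ccco3)c2)C1` gives 0% in this assay.
Compound 3 `CC(=O)c1cccc(NC(=O)C2CCCN(C(=O)c3cc(C(F)(F)F)cc(C(F)(F)F)c3)C2)c1` gives 0% in this assay.

All three measured compounds share the same core, and compound 2 stands level with compounds 1 and 3 in this assay, every reading sitting at the bottom of the scale. Going by the values given here, the only measured step, no change at the digits printed from compound 1 to compound 3 (within the scatter), swaps the group on the amide-type nitrogen and stays within the scatter. Among the compounds with values here, compound 4 `COc1cccc(C(=O)N2CCCC(C(=O)Nc3ccc(Cl)cc3)C2)c1` differs from compound 2 by methoxy in place of furan-2-yl on an aromatic carbon, a change touching a different group than that measured step, so no measured step covers it directly. Still, the flat reading of compound 2 at 0% and the flat step no change at the digits printed from compound 1 to compound 3 (within the scatter) give no sign of any cytotoxicity in this series. The expected step is therefore no change at the digits printed from compound 2 to compound 4 (within the scatter), none beyond the scatter. Compound 4 is estimated at 0% in this assay, between 0% and 10%.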

Compound 4, a percentage reported as inhibition, at one concentration (the size of the read-out at that concentration, not a potency): 0%
For compound 4 middle estimate and measured number coincide at the digits printed, and the stated range covers the measured number.
By their numbers in this assay, from the lowest: compounds 1, 2, 3 and 4 (each within the scatter of the next).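

At this aromatic carbon, methoxy in place of furan-2-yl gives no change at the digits printed from compound 2 to compound 4 (within the scatter) in this assay and so a five-membered aromatic ring can give way to a group with no ring while the reading stays at the bottom of the scale. Going by these compounds alone, the earlier step touched only the group on the amide-type nitrogen, which makes this the first look at this position. Nothing measured here offers a reason for this flat result.

From the compounds shown here alone, an amine or a carboxylic acid at this aromatic carbon remains open. Also open, going by these compounds, is whether any group on the shared core lifts the reading off the bottom of the scale, and readings that all sit there cannot rank groups.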